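Trifluoromethoxy added to compound 2

The source may hold more compounds than are shown below. What is called first, only, known or untested is meant among the compounds shown, and "the series" means these compounds.

Measured so far:
Compound 1 `COc1cc(NC(=O)/C=C/c2cccc(OCc3ccccc3)c2)cc(OC)c1OC`: 21700 nM
Compound 2 `C=C(Br)C(=O)Nc1cccc(/C=C/C(=O)Nc2ccccc2)c1`: 3900 nM

In a functional assay on LoVo cells (Homo sapiens) for inhibition, read by MTT assay, with a stated time of 72 h (on this read-out higher numbers stand for weaker inhibition and lower numbers for stronger inhibition), compound 2 gives 3900 nM, the lower of the two numbers. Its gap to compound 1 at 21700 nM lies beyond the scatter. These two compounds differ in more than one place, so the gap cannot be assigned to any single group.

Next is compound 3 `C=C(Br)C(=O)Nc1cccc(/C=C/C(=O)Nc2ccc(OC(F)(F)F)cc2)c1`, with trifluoromethoxy in place of hydrogen on an aromatic carbon, para to a large group: trifluoromethoxy in place of hydrogen on an aromatic carbon. Among the compounds with values here, no measured pair shows this change, so the expectation is weakly grounded: a small step in this assay toward stronger inhibition, likely within the scatter. The estimated step is a 1.6-fold lower number from compound 2 to compound 3 (0.19 log units; within the scatter). For compound 3 the estimated value is 2500 nM, with an expected range of 800 nM to 7000 nM.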

Compound 3, half-maximal inhibitory concentration: 30300 nM
Beside the measured number, compound 3's estimate is 12-fold (1.08 log units) below it; the measured number lies above the stated range.
By their numbers in this assay, from the lowest: compound 2; then compounds 1 and 3 (each within the scatter of the next).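

In this assay, within the data shown here, trifluoromethoxy in place of hydrogen gives a 7.8-fold higher number from compound 2 to compound 3 (0.89 log units; beyond the scatter) and provides the first comparison between compounds that differ in one place. The step runs toward weaker inhibition, which shows that this aromatic carbon, para to a large group, is not indifferent to substitution, at least for this one group. No measurement at hand bears on the reason for this step.

Still open, from the compounds shown here alone, is whether the weakening belongs to trifluoromethoxy alone or to any group at this carbon; fluorine, methoxy or an amine there would separate these two readings. Also open, going by these compounds, is whether the same change would give a step of similar size and direction on the core of compound 1.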